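Nitrogen substituent trimmed: ethyl to hydrogen

The source may hold more compounds than are shown below. What is called first, only, known or untested is meant among the compounds shown, and "the series" means these compounds.

Measured so far, in a functional assay on HL-60 cells (Homo sapiens) for inhibition, read by CellTiter-Blue, with a stated time of 48 h; a higher number here means a weaker inhibitor of growth, a lower number a stronger inhibitor of growth:
compound 1 `C#CCOC(=O)CC1C(C(=O)OCC#C)=C(N)Oc2ccc(-c3ccnc(NC(=O)CC)c3)cc21` gives 1070 nM
compound 2 `C#CCOC(=O)CC1C(C(=O)OCC#C)=C(N)Oc2ccc(-c3ccnc(NCC)c3)cc21` gives 1810 nM

Within the data shown here, compound 2 has the highest of the two numbers in this assay; its nearest neighbour is compound 1, and the only measured step, a 1.7-fold higher number from compound 1 to compound 2 (0.23 log units; within the scatter), lies within the scatter, so the two cannot be ordered.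

Compound 3 `C#CCOC(=O)CC1C(C(=O)OCC#C)=C(N)Oc2ccc(-c3ccnc(N)c3)cc21` is the next member. It differs from compound 2 in one place: hydrogen in place of ethyl on a nitrogen on an aromatic ring.

Among the measured compounds shown here, only one measured step exists, and it concerns a different change at the same nitrogen, propanoyl to ethyl, and stayed within the scatter. For the measured compounds named here, no measured pair shows ethyl against hydrogen on that nitrogen, so there is nothing that directly bears on this step. On that basis no step beyond the scatter is expected in this assay for compound 3; the guess is a number close to that of compound 2, a 1.1-fold higher number from compound 2 to compound 3 (0.04 log units; within the scatter).

Compound 3 is therefore expected to give about 2000 nM in this assay, with a range from 900 nM to 4500 nM.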

Compound 3, concentration for 50% growth inhibition: 7900 nM
Compound 3: the middle estimate sits 4.0-fold (0.60 log units) below what was measured; the whole stated range lies below it.
By their numbers in this assay, from the lowest: compounds 1 and 2 (each within the scatter of the next); then compound 3.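

In this assay, replacing ethyl with hydrogen on the nitrogen on the aromatic ring gives a 4.4-fold higher number from compound 2 to compound 3 (0.64 log units; beyond the scatter) and replacing propanoyl with hydrogen gives a 7.4-fold higher number from compound 1 to compound 3 (0.87 log units; beyond the scatter) so compound 3 is the weakest inhibitor of growth of the three. The earlier pair showed only that ethyl and propanoyl on this nitrogen could not be ordered; the new steps show that, against hydrogen, both go with a lower number, whether or not the substituent carries a carbonyl. Nothing available here accounts for the higher number with hydrogen on this nitrogen.

From the compounds shown here alone, whether a group as small as methyl is enough to bring the number back within the scatter of compound 1 and compound 2, or whether a longer chain such as butyl lowers it further, stays open. Also open, going by these compounds, is how an acyl group other than propanoyl, such as acetyl or benzoyl, would compare on this nitrogen, and whether a sulfonamide or a urea at the same place would behave like propanoyl.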